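Working notes: ester-bearing ring back to a fused bicyclic

A few compounds are considered here, and "the series" means these few. Any claim that something is new, unique, unknown or untested is made for them only; others in the source may bear on it.

Compound 2 `COC(=O)[C@H]1C=C[C@@H](Nc2ncnc3c2nnn3[C@@H]2C[C@@H](COS(N)(=O)=O)[C@@H](O)C2)C1` gives 80.9 nM in an assay on a protein complex for inhibition of NEDD8 activating enzyme (Homo sapiens), read by HTRF, with a stated time of 2 h, in the presence of a further agent that is not named here (a higher number here means a weaker inhibitor, a lower number a stronger inhibitor), the highest of the two numbers recorded so far. Compound 1 `NS(=O)(=O)OC[C@@H]1C[C@@H](n2nnc3c(N[C@H]4CCc5ccccc54)ncnc32)C[C@@H]1O` gives 0.21 nM in this assay. Among the measured compounds shown here, the one recorded step, a 390-fold higher number from compound 1 to compound 2 (2.59 log units; beyond the scatter), shows that the group on the nitrogen on the aromatic ring moves the number strongly.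

Compound 3 `NS(=O)(=O)OC[C@@H]1C[C@@H](n2nnc3c(N[C@@H]4c5ccccc5C[C@@H]4O)ncnc32)C[C@@H]1O` differs from compound 2 in one place: a group of 10 heavy atoms (9 carbon, 1 oxygen; one five-membered non-aromatic ring of carbon only, one six-membered aromatic ring of carbon only) in place of a group of 9 heavy atoms (7 carbon, 2 oxygen; one five-membered non-aromatic ring of carbon only), on a nitrogen on an aromatic ring. The entering group, like the group of compound 1, holds a five-membered non-aromatic ring fused to a six-membered aromatic ring, with a single hydroxyl added. For the measured compounds named here, that single recorded step is the only guide, and it points toward a large decrease in this assay on returning to a fused bicyclic group.

In this assay compound 3 is expected to give about 0.6 nM, within 0.1 nM to 4 nM. The expected step is a 130-fold lower number from compound 2 to compound 3 (2.13 log units; beyond the scatter), a reversal of most of the increase seen between compound 1 and compound 2.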

Compound 3, half-maximal inhibitory concentration: 2.28 nM
Estimate against measurement, compound 3: 3.8-fold (0.58 log units) below; the measured number falls inside the stated range.
By their numbers in this assay, from the lowest: compound 1; then compound 3; then compound 2.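

In this assay, the step of a 35-fold lower number from compound 2 to compound 3 (1.55 log units; beyond the scatter) shows that a group with a six-membered aromatic ring and a five-membered non-aromatic ring, on a nitrogen on an aromatic ring, gives a much lower number than the ester-bearing group even when it carries a hydroxy group. The step of an 11-fold higher number from compound 1 to compound 3 (1.04 log units; beyond the scatter) adds what the earlier pair could not show: within the fused group, hydroxy in place of hydrogen on a saturated ring carbon is enough on its own to move the number beyond the scatter. No measurement given here explains either step.

Going by these compounds, it remains open how an amine, a methoxy group or fluorine would compare with hydroxy on that saturated ring carbon. On these data alone, the effect of the opposite stereochemistry at the two defined stereocentres of the entering group also remains open.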